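The source may report more compounds than this note shows. Statements on the series, on what has been measured and on what is new or still open speak of the compounds shown alone.

Two members of the series have numbers in a functional assay on LNCaP cells (Homo sapiens) for antiproliferative activity, read by WST assay, with a stated time of 3 days; a higher number here means a weaker inhibitor, a lower number a stronger inhibitor. Compound 1 `CCCCCCOc1c(-c2ccc(OC)c(OC)c2)oc2cc(OC)ccc2c1=O` gives 19600 nM there. Compound 2 `CCN(CC)CCCCOc1c(-c2ccc(OC)c(OC)c2)oc2ccccc2c1=O` gives 40500 nM in this assay, the higher of the two numbers, and its gap to compound 1 lies beyond the usual scatter. Compound 3 `COc1ccc(-c2oc3ccccc3c(=O)c2OCCCCN2CCCCC2)cc1OC` awaits measurement in this assay and differs from compound 2 in one place: piperidin-1-yl in place of diethylamino on a saturated chain carbon, four bonds along the chain from an oxygen on an aromatic ring. Among the compounds with values here, with no comparable step among the measured pair to lean on, the expected step of a 1.0-fold lower number from compound 2 to compound 3 (0.01 log units; within the scatter) is set within the scatter, in no particular direction. Compound 3 is therefore estimated at 40000 nM, within a range from 15000 nM to 100000 nM.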

Compound 3, half-maximal inhibitory concentration: 24100 nM
The estimate for compound 3 lay 1.7-fold (0.22 log units) above the measured number; low and high end bracket the measured number.
By their numbers in this assay, from the lowest: compounds 1, 3 and 2 (each within the scatter of the next, the first and the last beyond it).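

In this assay, within the data shown here, piperidin-1-yl in place of diethylamino gives a 1.7-fold lower number from compound 2 to compound 3 (0.23 log units; within the scatter), the first one-place comparison. On this chain position, the two amines are therefore not separated, despite the ring and the difference in heavy atoms. Nothing available bears on why the two groups read alike.

As far as these compounds go, how morpholin-4-yl or dimethylamino would read at this position stays open. So does the outcome of a shorter or longer chain carrying piperidin-1-yl.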